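From Fluoro to Methoxy at the Limit

The source may hold more compounds than are shown below. What is called first, only, known or untested is meant among the compounds shown, and "the series" means these compounds.

In a functional assay on MCF7 cells (Homo sapiens) for cytotoxicity, read by MTT assay, with a stated time of 72 h (on this read-out higher numbers stand for weaker inhibition and lower numbers for stronger inhibition), compound 1 `CNC(=O)c1cc(Oc2ccc(NC(=O)c3cc(-c4ccc(C(F)(F)F)cc4)ncn3)cc2F)ccn1` gives > 100000 nM, which is a limit and not a number. Compound 2 `CNC(=O)c1cc(Oc2ccc(NC(=O)c3cc(-c4ccc(F)cc4)ncn3)cc2F)ccn1` gives > 100000 nM, again a limit. Compound 2 therefore stands at the limit of > 100000 nM in this assay, at which 2 of the 2 values shown sit. Compound 3 `CNC(=O)c1cc(Oc2ccc(NC(=O)c3cc(-c4ccc(OC)cc4)ncn3)cc2F)ccn1` carries methoxy in place of fluoro on an aromatic carbon. For the measured compounds named here, the one measured change bearing on this is a step that the two limits leave unreadable from compound 1 to compound 2. Since a step that the two limits leave unreadable from compound 1 to compound 2 offers no size to carry forward, no step beyond the scatter is expected in this assay. The estimated result is a number no higher from compound 2 to compound 3 (the limit leaves the size open). Compound 3 is expected near 100000 nM, with an estimated range from 40000 nM to 200000 nM.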

Compound 3, half-maximal inhibitory concentration: 46200 nM
The estimate for compound 3 lay 2.2-fold (0.34 log units) above the measured number; the range from low to high includes it.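

In this assay, methoxy on this aromatic carbon gives a readable number where the earlier groups did not, with an at least 2.1-fold lower number from compound 2 to compound 3 (0.33 log units; beyond the scatter) and an at least 2.1-fold lower number from compound 1 to compound 3 (0.33 log units; beyond the scatter). Going by these compounds, the true size of both steps stays open, but the position can move the read-out. Compound 1 and compound 2 both rest on a limit, and the step between them cannot be read: the limit of > 100000 nM in this assay, at which 2 of the 3 values shown sit.

On these data alone, whether an amine, a hydroxyl or a longer chain such as ethoxy on this carbon would lower the number further remains open. So does whether the gain belongs to methoxy alone.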